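A methoxy added to compound 3

The source may report more compounds than this note shows. Statements on the series, on what has been measured and on what is new or still open speak of the compounds shown alone.

In an ADME assay on a cell-free system (plasma, Rattus norvegicus) for metabolic stability, read by LC-MS, with a stated time of 60 min, tested at 100 uM (on this read-out lower numbers stand for a less stable compound and higher numbers for a more stable compound), the measured compounds stand as follows.
Compound 1 `CCCC(=O)c1ccc(OCCCCOc2cc(C(=O)O)ccc2OC)c(C)c1O` gives 78%
Compound 2 `COc1ccc(C(=O)O)cc1OCCCCOc1ccc(C(=O)CC2CCCC2)c(O)c1C` gives 103%
Compound 3 `Cc1c(OCCCCOc2cccc(C(=O)O)c2)ccc(C(=O)CC(C)C)c1O` gives 100%

In this assay compound 3 lies within the scatter of compound 2 and beyond the scatter from compound 1, on the higher side. Compound 4 `COc1ccc(C(=O)O)cc1OCCCCOc1ccc(C(=O)CC(C)C)c(O)c1C` is compound 3 with one change, methoxy in place of hydrogen on an aromatic carbon.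

Among the compounds with values here, no measured step covers this change. Within the data shown here, the only step available is a number 25 percentage points higher from compound 1 to compound 2 (beyond the scatter) for cyclopentyl in place of ethyl on a saturated chain carbon bound to a carbonyl carbon, which is a change at another place. Compound 2 carries the same methoxy and gives 103% while compound 1 also carries it and gives 78% so the group alone does not settle the value. The expected move is a number 4 percentage points lower from compound 3 to compound 4 (within the scatter) and no step beyond the scatter is anticipated. For compound 4 the estimate is 96% with an expected range of 80% to 108% around it.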

Compound 4, percent of the compound remaining: 99%
Compound 4: the middle estimate sits 3 percentage points below what was measured, and the stated range covers the measured number.
By their numbers in this assay, from the lowest: compound 1; then compounds 4, 3 and 2 (each within the scatter of the next).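

In this assay methoxy in place of hydrogen on this aromatic carbon, ortho to a large group and para to a carboxy group, gives a number 1 percentage points lower from compound 3 to compound 4 (within the scatter) and so cannot be told apart from repeat scatter when the chain on the carbonyl ends in isopropyl. Among the compounds carrying this methoxy, the chain separates them only in part, with a number 4 percentage points lower from compound 2 to compound 4 (within the scatter) for isopropyl in place of cyclopentyl but a number 21 percentage points higher from compound 1 to compound 4 (beyond the scatter) for the added chain methyl. No evidence given here accounts for these numbers.

Going by these compounds, whether this aromatic carbon tolerates a hydroxy, a fluorine or a longer ether such as ethoxy equally well remains open. So does how the methoxy behaves alongside the shorter chain of compound 1.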